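Benzyl amide variation on the shared indazole-free core series

A few compounds are considered here, and "the series" means these few. Any claim that something is new, unique, unknown or untested is made for them only; others in the source may bear on it.

Measured compounds:
compound 1 `CN(Cc1ccccc1F)C(=O)c1cc2c(Cc3ccccc3)n[nH]c2cc1O` with 1500 nM
compound 2 `CN(Cc1cccc(F)c1)C(=O)c1cc2c(Cc3ccccc3)n[nH]c2cc1O` with 5000 nM
compound 3 `Cc1cccc(CN(C)C(=O)c2cc3c(Cc4ccccc4)n[nH]c3cc2O)c1` with "not determined" (no result reported)

In a functional assay on A2780 cells (Homo sapiens) for antiproliferative activity, read by resazurin assay, with a stated time of 72 h (on this read-out lower numbers stand for stronger inhibition and higher numbers for weaker inhibition), compound 1 gives 1500 nM, the lowest number of the two measured entries; compound 2 gives 5000 nM, and the step of a 3.3-fold higher number from compound 1 to compound 2 (0.52 log units; beyond the scatter) is modest but beyond the scatter. For compound 3 the result in this assay is "not determined" (no result reported). Compound 4 `COc1cccc(CN(C)C(=O)c2cc3c(Cc4ccccc4)n[nH]c3cc2O)c1OC` differs from compound 1 by 2,3-dimethoxyphenyl in place of 2-fluorophenyl on a saturated chain carbon bound to an amide-type nitrogen. For the measured compounds named here, only the step from compound 1 to compound 2 bears on this change, and it carries no information about methoxy groups. Given that moving a substituent away from the position it has in compound 1 cost a 3.3-fold higher number from compound 1 to compound 2 (0.52 log units; beyond the scatter), a small loss is expected for compound 4, roughly a 1.7-fold higher number from compound 1 to compound 4 (0.22 log units; within the scatter). Compound 4 is therefore estimated at 2500 nM, with a range from 800 nM to 8000 nM.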

Compound 4, half-maximal inhibitory concentration: 4800 nM
Estimate against measurement, compound 4: 1.9-fold (0.28 log units) below; the range from low to high includes it.
By their numbers in this assay, from the lowest: compound 1; then compounds 4 and 2 (each within the scatter of the next).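

In this assay, 2,3-dimethoxyphenyl gives a 3.2-fold higher number from compound 1 to compound 4 (0.51 log units; beyond the scatter) and a 1.0-fold lower number from compound 2 to compound 4 (0.02 log units; within the scatter). Two different replacements of 2-fluorophenyl on the saturated chain carbon thus lie within the scatter of each other, and compound 1 keeps the lowest number of the three. The added heavy atoms and two hydrogen-bond acceptors of the dimethoxy group bring no step beyond the scatter relative to compound 2, and nothing available accounts for these steps.

Whether the fluorine of compound 1 matters remains open, since unsubstituted phenyl and chlorophenyl are not among the compounds shown. As far as these compounds go, how a pyridine ring or an amine-bearing benzyl group would behave at this position also remains open.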